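Working notes: thiazolyl to dimethylpyrimidinyl, from compound 3 to compound 4

The source may report more compounds than this note shows. Statements on the series, on what has been measured and on what is new or still open speak of the compounds shown alone.

Measured so far:
compound 1 `O=c1oc2ccccc2c(Cl)c1/C=N/c1ccc(S(=O)(=O)Nc2nccs2)cc1`; in a functional assay on B16-F10 cells (Mus musculus) for cytotoxicity, read by CCK-8 assay, with a stated time of 48 h (on this read-out lower numbers stand for stronger inhibition and higher numbers for weaker inhibition), compound 1 gives 300 nM
compound 2 `Cc1cc(C)nc(NS(=O)(=O)c2ccc(/N=C/c3c(Cl)c4ccccc4oc3=O)cc2)n1`; in this assay compound 2 gives 170 nM
compound 3 `Cc1ccc2oc(=O)c(/C=N/c3ccc(S(=O)(=O)Nc4nccs4)cc3)c(Cl)c2c1`; in this assay compound 3 gives 280 nM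

Compound 3 stands second highest of the three numbers. Its nearest neighbour is compound 1, from which it differs only by a methyl in place of hydrogen on an aromatic carbon, a step of a 1.1-fold lower number from compound 1 to compound 3 (0.03 log units; within the scatter). The gap between compound 3 and compound 2 is also within the scatter, so no order is read among the three.

Compound 4 `Cc1ccc2oc(=O)c(/C=N/c3ccc(S(=O)(=O)Nc4nc(C)cc(C)n4)cc3)c(Cl)c2c1` is not yet measured in this assay. It differs from compound 3 in one place: 4,6-dimethylpyrimidin-2-yl in place of 1,3-thiazol-2-yl on a sulfonamide nitrogen. The same exchange has been made once before, on compound 1 to give compound 2, where it read a 1.8-fold lower number from compound 1 to compound 2 (0.25 log units; within the scatter). Among the measured compounds shown here, that is the only step that bears on the present one; it was within the scatter, so no move beyond the scatter is firmly expected, only a possible small shift toward a lower number in the same direction.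

Compound 4 is therefore estimated at 160 nM, with a range from 80 nM to 320 nM, which amounts to an expected step of a 1.8-fold lower number from compound 3 to compound 4 (0.24 log units; within the scatter).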

Compound 4, half-maximal inhibitory concentration: 300 nM
Beside the measured number, compound 4's estimate is 1.9-fold (0.27 log units) below it; low and high end bracket the measured number.
By their numbers in this assay, from the lowest: compounds 2, 3, 1 and 4 (each within the scatter of the next).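

In this assay, the exchange of 1,3-thiazol-2-yl for 4,6-dimethylpyrimidin-2-yl on the sulfonamide nitrogen now has a reading on a second core, a 1.1-fold higher number from compound 3 to compound 4 (0.03 log units; within the scatter), and the two readings of this exchange agree within the scatter: the same change on two cores in this assay, a 1.8-fold lower number (0.25 log units; within the scatter) from compound 1 to compound 2 and a 1.1-fold higher number (0.03 log units; within the scatter) from compound 3 to compound 4, 1.9-fold (0.28 log units) apart, within the scatter of two such steps

The methyl in place of hydrogen on an aromatic carbon also has a second reading, now with 4,6-dimethylpyrimidin-2-yl on the sulfonamide nitrogen, a 1.8-fold higher number from compound 2 to compound 4 (0.25 log units; within the scatter), and again the two readings agree: the same change on two cores in this assay, a 1.1-fold lower number (0.03 log units; within the scatter) from compound 1 to compound 3 and a 1.8-fold higher number (0.25 log units; within the scatter) from compound 2 to compound 4, 1.9-fold (0.28 log units) apart, within the scatter of two such steps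

Across these four compounds, neither change gives a step beyond the scatter on either core, so the larger 4,6-dimethylpyrimidin-2-yl and the added methyl can be combined with no departure from the scatter in this read-out.

Among the compounds shown here, whether the sulfonamide nitrogen would give a step beyond the scatter with a group of another kind, such as a short alkyl chain or a chain ending in a carboxylic acid, stays open, as only two aromatic rings appear there. The same holds for the aromatic carbon, where only hydrogen and methyl appear and a fluorine or a methoxy group would be a further test.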